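From Trifluoromethoxy to Ethoxy: Predicting Compound 4

This account rests on a few compounds, and the source may have more. Where it says the series, first, only, none or still open, it means among the compounds named here.

Three compounds share one core and differ in a single group on an aromatic carbon. In a functional assay on Jurkat cells (Homo sapiens) for antiproliferative activity, read by MTT assay, with a stated time of 72 h (on this read-out higher numbers stand for weaker inhibition and lower numbers for stronger inhibition), compound 1 `COc1cc(-n2ncnc2-c2ccc(C)cc2)cc(OC)c1OC`, which carries methyl, gives 300 nM. Compound 2 `COc1cc(-n2ncnc2-c2ccc(Cl)cc2)cc(OC)c1OC`, which carries chloro, reads > 10000 nM, a limit of the assay and not a number. Compound 3 `COc1cc(-n2ncnc2-c2ccc(OC(F)(F)F)cc2)cc(OC)c1OC`, which carries trifluoromethoxy, reads > 10000 nM, and this too is a limit. Compound 3 therefore sits at the limit of > 10000 nM in this assay, at which 2 of the 3 values shown sit.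

Compound 4 `CCOc1ccc(-c2ncnn2-c2cc(OC)c(OC)c(OC)c2)cc1` changes one group of compound 3: ethyl in place of trifluoromethyl on an oxygen on an aromatic ring. Trifluoromethoxy thus becomes ethoxy. For the measured compounds named here, no measured step makes this exact change, so the nearest evidence is indirect. The change to compound 3 was large, an at least 33-fold higher number from compound 1 to compound 3 (1.52 log units; beyond the scatter), and the change to compound 2 was equally large, an at least 33-fold higher number from compound 1 to compound 2 (1.52 log units; beyond the scatter). Going by the values given here, only methyl, the one group here without a halogen, gave a measurable number, and ethoxy also lacks a halogen. That is a thin pattern, resting on three compounds, but it points toward a large step to a lower number in this assay. Compound 4 could still remain at the limit. The step expected is an at least 20-fold lower number from compound 3 to compound 4 (1.30 log units; beyond the scatter). For compound 4 the estimated value is 500 nM, with an expected range from 30 nM to 8000 nM.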

Compound 4, half-maximal inhibitory concentration: 5 nM
Compound 4: middle estimate off by 100-fold (2.00 log units), on the high side; measured number below the stated range.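

Replacing trifluoromethyl with ethyl on the oxygen produces, in this assay, an at least 2000-fold lower number from compound 3 to compound 4 (3.30 log units; beyond the scatter) and the comparison with chloro gives an at least 2000-fold lower number from compound 2 to compound 4 (3.30 log units; beyond the scatter) as well; both sizes are only minimums, since each starting compound sits at a limit and has no exact number. The earlier compounds shown here could not show that any group on this aromatic carbon gives a lower number than methyl, yet ethoxy gives a 60-fold lower number from compound 1 to compound 4 (1.78 log units; beyond the scatter) and so replaces methyl as the group with the lowest number in the set. An oxygen attached to the aromatic carbon does not settle the outcome by itself, as trifluoromethoxy and ethoxy both have one, and the step between compound 2 and compound 3 cannot be read: the limit of > 10000 nM in this assay, at which 2 of the 4 values shown sit.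

Ethoxy is the only group shown that has an oxygen and no halogen, so it remains open whether methoxy, a longer propoxy chain or an amine on this aromatic carbon would give a similarly low number. Chloro and trifluoromethoxy are the only halogen-bearing groups here and both stop at the limit, so difluoromethoxy or fluoro would test whether that split holds beyond these four compounds.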